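A cyano group added to compound 3

A few compounds are considered here, and "the series" means these few. Any claim that something is new, unique, unknown or untested is made for them only; others in the source may bear on it.

Three compounds built around a similar core have numbers in a functional assay on SMMC-7721 cells (Homo sapiens) for cytotoxicity, read by MTT assay, with a stated time of 24 h; on this read-out lower numbers stand for stronger inhibition and higher numbers for weaker inhibition. Compound 1 (`COc1cc(/C=C2\CN(C)C/C(=C\c3ccncc3)C2=O)cc(OC)c1OC`) gives 9130 nM, and compound 2 (`COc1ccc(/C=C2\CN(C)C/C(=C\c3ccncc3)C2=O)c(OC)c1OC`) gives 9080 nM, two values that lie within the scatter of each other. Compound 3 (`O=C1/C(=C/c2cccnc2)CN(S(=O)(=O)c2ccccc2)C/C1=C\c1ccccc1F`) gives 19100 nM, the highest number of the three, and it stands beyond the scatter from both compound 1 and compound 2, though only narrowly.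

Compound 4 (`N#Cc1ccc(S(=O)(=O)N2C/C(=C\c3cccnc3)C(=O)/C(=C/c3ccccc3F)C2)cc1`) has not yet been measured. It differs from compound 3 in one place: cyano in place of hydrogen on an aromatic carbon. This places cyano in place of hydrogen on an aromatic carbon, para to a large group, so that phenylsulfonyl becomes (4-cyanophenyl)sulfonyl.

Among the compounds with values here, no measured pair shows this change, so its effect in this assay has no direct precedent. Within the data shown here, the only guide is the narrow spread of the numbers, with compound 1 at 9130 nM and compound 3 at 19100 nM. A small move toward a lower number is therefore expected, one that stays within the scatter. The estimated change is a 1.4-fold lower number from compound 3 to compound 4 (0.13 log units; within the scatter). Compound 4 is expected at 14000 nM, with an estimated range of 6000 nM to 30000 nM.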

Compound 4, half-maximal inhibitory concentration: 15400 nM
Compound 4: middle estimate off by 1.1-fold (0.04 log units), on the low side; low and high end bracket the measured number.
By their numbers in this assay, from the lowest: compounds 2, 1, 4 and 3 (each within the scatter of the next, the first and the last beyond it).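

In this assay, within the data shown here, the change from phenylsulfonyl to (4-cyanophenyl)sulfonyl gives the first comparison in this set between compounds that differ in one place, and it reads a 1.2-fold lower number from compound 3 to compound 4 (0.09 log units; within the scatter). Placed on this six-membered aromatic ring, para to a large group, the cyano group therefore brings no shift that can be told apart from the usual scatter of repeated measurements, something the earlier compounds, with no such pair among them, could not show. No measurement of any property of these compounds bears on this result, so the flat step comes with no established explanation.

This single step covers one group in one place, and it leaves open whether the same position would stay as flat with an amine, a carboxylic acid or a methoxy group in place of the hydrogen. It also leaves open whether a cyano group elsewhere on the phenyl ring, or on the fluorinated phenyl ring at the other end of the shared core, would move the number beyond the scatter.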